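A few compounds are considered here, and "the series" means these few. Any claim that something is new, unique, unknown or untested is made for them only; others in the source may bear on it.

Compound 1 `COC(=O)c1cc(=O)c2cc(NC(=O)Nc3ccc(F)c(Cl)c3)ccc2[nH]1` gives in a functional assay on SEM cells (Homo sapiens) for antiproliferative activity, with a stated time of 72 h (on this read-out higher numbers stand for an effect only at larger amounts of compound and lower numbers for an effect already at smaller amounts), the value > 6350 nM, which is a limit of the assay.
Compound 2 `COC(=O)c1cc(=O)c2cc(NC(=O)Nc3cccc(C(C)=O)c3)ccc2[nH]1` gives in this assay the value > 8080 nM, again a limit of the assay.
Compound 3 `COC(=O)c1cc(=O)c2cc(NC(=O)NCc3ccccc3)ccc2[nH]1` gives in this assay the value > 19500 nM, also a limit of the assay.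

Compound 3 therefore stands nowhere exactly on the numbers shown: it has only a limit, and the two other values are limits as well. The new compound 4 `COC(=O)c1cc(=O)c2cc(NC(=O)Nc3ccc4c(c3)CCC4)ccc2[nH]1` differs from compound 3 by 2,3-dihydro-1H-inden-5-yl in place of benzyl on an amide-type nitrogen. The measured steps that bear on this are a step that the two limits leave unreadable from compound 1 to compound 3, a step that the two limits leave unreadable from compound 2 to compound 3 and a step that the two limits leave unreadable from compound 1 to compound 2; none of them has a readable size, since every compound sits at a limit, as seen in the limit of > 19500 nM in this assay, at which 1 of the 3 values shown sits, the limit of > 6350 nM in this assay, at which 1 of the 3 values shown sits, and (the limit of > 8080 nM in this assay, at which 1 of the 3 values shown sits). With three aryl or benzyl groups on this nitrogen all giving only limits, no direction can be read for the change to 2,3-dihydro-1H-inden-5-yl, and the expected step of an at least 1.3-fold lower number from compound 3 to compound 4 (0.11 log units; that floor lies within the scatter) is set near no change. Compound 4 is therefore estimated at 15000 nM, within the range 4000 nM to 50000 nM, most likely again reported only as a limit.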

Compound 4, half-maximal effective concentration: > 24100 nM
Compound 4: no number, only a limit; the forecaster's own chance of this, stated with the estimate: 70%; middle value at least 1.6-fold (0.20 log units) away from the limit.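

Compound 4, like compound 1, compound 2 and compound 3, gives only a limit of the assay, so none of its steps to those three compounds can be read. The compounds shown leave open how the group on the amide-type nitrogen changes the effect in this assay.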